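The source may hold more compounds than are shown below. What is called first, only, known or untested is meant among the compounds shown, and "the series" means these compounds.

Working notes on the series, values from a physicochemical assay for solubility; a higher number here means a more soluble compound, a lower number a less soluble compound:

- Compound 1 `Cc1c2c(n3c1CCN(C(=O)[C@H](C)N)CC[C@H](C)Nc1cc-3ccc1C(N)=O)CC(C)(C)CC2=O`: > 100 ug/mL (a limit)
- Compound 2 `Cc1c2c(n3c1CC(=O)NCC[C@H](C)Nc1cc-3ccc1C(N)=O)CC(C)(C)CC2=O`: > 100 ug/mL (a limit)
- Compound 3 `Cc1c2c(n3c1CCCN(CCN)C(=O)[C@H](C)Nc1cc-3ccc1C(N)=O)CC(C)(C)CC2=O`: > 100 ug/mL (a limit)

Compound 1 has no numerical value here, only the limit > 100 ug/mL. The same holds across the set: the limit of > 100 ug/mL in this assay, at which 3 of the 3 values shown sit. The true distance of any of these compounds from that limit is unknown, and no step between measured compounds is available to size a change.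

The next compound to be read is compound 4 `CC(=O)N1CCc2c(C)c3c(n2-c2ccc(C(N)=O)c(c2)N[C@@H](C)CC1)CC(C)(C)CC3=O`, which has methyl in place of 1-aminoethyl on a carbonyl carbon. The cut one bond further out reads (1-aminoethyl)carbonyl to acetyl.

In this assay, a modest downward step is expected, though it may stay within the scatter, and the result may again be only a limit. The estimated step is an at least 1.2-fold lower number from compound 1 to compound 4 (0.09 log units; that floor lies within the scatter). This expectation rests on the structural change alone and is loosely bounded. For compound 4 the expected value is 80 ug/mL, with an estimated range of 25 ug/mL to 150 ug/mL.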

Compound 4, solubility: 19 ug/mL
Estimate against measurement, compound 4: 4.2-fold (0.62 log units) above; measured number below the stated range.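

In this assay, among these compounds, compound 4 gives the only value shown that is not a limit, so a change at this position can now be given a lower bound. Methyl in place of 1-aminoethyl on a carbonyl carbon gives an at least 5.2-fold lower number from compound 1 to compound 4 (0.72 log units; beyond the scatter), which shows that the shared core does not keep a compound at the limit whatever group this carbonyl carries. The true size of the step remains unknown because its starting point is not a number: the limit of > 100 ug/mL in this assay, at which 3 of the 4 values shown sit.

As far as these compounds go, it remains open how much of the step belongs to the amine of 1-aminoethyl and how much to its carbon portion. Also open, from the compounds shown here alone, is how an aminomethyl group, a hydroxyethyl group or a carboxylic acid on the same carbonyl carbon would read.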